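A Dichlorophenyl Swap on Compound 2

The compounds below may be only part of what the source reports. "The series", "measured", "known", "first", "only" and "open" are said of these compounds alone.

In a physicochemical assay for lipophilicity, at pH 7.4 (a lower number here means a more polar compound, a higher number a more lipophilic compound), compound 2 `N#Cc1ccc(S(=O)(=O)[C@H]2CN(S(=O)(=O)c3ccc(Cl)cn3)C[C@@]2(O)CO)cc1` gives 3.1, the lowest of the three measured numbers. It stands clearly apart from compound 3 `N#Cc1ccc(O[C@H]2CN(S(=O)(=O)c3ccc(C(F)(F)F)nc3)C[C@@]2(O)CO)cc1F` at 4.2 and compound 1 `N#Cc1ccc(O[C@H]2CN(S(=O)(=O)c3ccc(C(F)(F)F)cc3)C[C@@]2(O)CO)cc1F` at 4.5. Compound 4 `N#Cc1ccc(S(=O)(=O)[C@H]2CN(S(=O)(=O)c3ccc(Cl)cc3Cl)C[C@@]2(O)CO)cc1` carries 2,4-dichlorophenyl in place of 5-chloropyridin-2-yl on a sulfonyl sulfur. Going by the values given here, only one measured step exchanges a pyridine ring and a carbon-only ring: a number 0.30 log units lower from compound 1 to compound 3 (within the scatter), which lies within the scatter and runs in the opposite sense, with the pyridine entering. Among the compounds with values here, no measured step isolates the chlorine change, so this guide is only partial. A rise larger than that step is expected, and the estimated change is a number 0.90 log units higher from compound 2 to compound 4 (beyond the scatter). The estimate for compound 4 is 4, with an expected range of 3.5 to 4.6.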

Compound 4, distribution coefficient: 4.5
Compound 4: middle estimate off by 0.50 log units, on the low side; the range from low to high includes it.
By their numbers in this assay, from the lowest: compound 2; then compounds 3, 1 and 4 (each within the scatter of the next).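

In this assay the ring on this sulfonyl sulfur can clearly move the number: 2,4-dichlorophenyl in place of 5-chloropyridin-2-yl gives a number 1.40 log units higher from compound 2 to compound 4 (beyond the scatter) in one step. Going by these compounds alone, the only earlier exchange of a pyridine ring and a carbon-only ring gave a number 0.30 log units lower from compound 1 to compound 3 (within the scatter) and involved no added chlorine. No measurement shown explains the size of the new step.

The compounds shown cannot divide this step between the ring exchange and the added chlorine. From the compounds shown here alone, how a phenyl ring carrying an amine or a carboxylic acid would read here also remains open.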